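Adding a Methoxy to a Trimethoxyphenyl Urea

The compounds below may be only part of what the source reports. "The series", "measured", "known", "first", "only" and "open" are said of these compounds alone.

Compound 1 `COc1cc(NC(=O)Nc2ccccc2)cc(OC)c1OC` has no number yet: for compound 1 the entry in a functional assay on Daoy cells (Homo sapiens) for cytotoxicity, read by MTT assay, with a stated time of 72 h (a higher number here means a weaker inhibitor, a lower number a stronger inhibitor), reads "not determined" (no result reported). A related amide, compound 2 `COc1cc(N(C)C(=O)c2ccc(F)cc2)cc(OC)c1OC`, is reported only as a limit of the assay, giving >= 125000 nM in this assay. Because (the limit of >= 125000 nM in this assay, at which 1 of the 2 values shown sits), the one result available is a limit, not a measured value. Compound 3 `COc1ccc(NC(=O)Nc2cc(OC)c(OC)c(OC)c2)cc1` differs from compound 1 by methoxy in place of hydrogen on an aromatic carbon. Among the measured compounds shown here, no measured step exists to set the size of this change, so any step in this assay may stay within the scatter. Compound 3 is expected to give about 50000 nM, estimated between 5000 nM and 200000 nM.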

Compound 3, half-maximal inhibitory concentration: 14900 nM
The estimate for compound 3 lay 3.4-fold (0.53 log units) above the measured number; the range from low to high includes it.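

Among the compounds shown here, compound 1 and compound 3 give no step that can be read in this assay, since only compound 3 has a number. On these data alone, the size of the change from phenyl to 4-methoxyphenyl stays open.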